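The source may report more compounds than this note shows. Statements on the series, on what has been measured and on what is new or still open speak of the compounds shown alone.

Among the measured compounds shown here, compound 2 `CCCNc1nc(C)nc2c1cnn2-c1ccccc1` is the one member of this small set that returns a definite number in a functional assay on G-361 cells (Homo sapiens) for cytotoxicity, read by sulforhodamine B assay; a lower number here means a stronger inhibitor of growth, a higher number a weaker inhibitor of growth: compound 2 gives 36000 nM. Compound 1 `CCCNc1ncnc2c1cnn2-c1ccccc1` reaches only the limit of this assay, > 100000 nM. Compound 3 `Cc1nc(NCc2ccccc2)c2cnn(-c3ccccc3)c2n1` likewise stops at the limit, > 100000 nM. Two steps have been measured: an at least 2.7-fold lower number from compound 1 to compound 2 (0.44 log units; beyond the scatter), and an at least 2.7-fold higher number from compound 2 to compound 3 (0.44 log units; beyond the scatter). Each shows that a single change on this core shifts the number beyond the scatter, but both touch different places than the change now in question, and their size is bounded by the limit of > 100000 nM in this assay, at which 2 of the 3 values shown sit.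

Compound 4 `CCCNc1nc(NCCC)c2cnn(-c3ccccc3)c2n1` differs from compound 2 by propylamino in place of methyl on an aromatic carbon. For the measured compounds named here, no measured step shows an amino chain entering at that aromatic carbon, so the direction of the change is open; the two measured steps only warn that the number can move beyond the scatter either way. Compound 4 is therefore expected to give about 40000 nM, with a wide range from 10000 nM to 160000 nM. This expectation for compound 4 amounts to a 1.1-fold higher number from compound 2 to compound 4 (0.05 log units; within the scatter), with a real chance that only a limit is returned.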

Compound 4, concentration for 50% growth inhibition: > 100000 nM
Compound 4: a limit, no number; the forecaster's own chance of this, stated with the estimate: 40%; middle value at least 2.5-fold (0.39 log units) away from the limit.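

Propylamino in place of methyl on the aromatic carbon between two ring nitrogen atoms gives an at least 2.7-fold higher number from compound 2 to compound 4 (0.44 log units; beyond the scatter) in this assay. Read alongside an at least 2.7-fold lower number from compound 1 to compound 2 (0.44 log units; beyond the scatter), this shows that the gain at this carbon does not carry over from methyl to every group placed there: among compound 1, compound 2 and compound 4, only methyl gives a definite number. The step from compound 1 to compound 4 cannot be read because both compounds stand at a limit: the limit of > 100000 nM in this assay, at which 3 of the 4 values shown sit.

The compounds shown leave open whether the nitrogen of the propylamino group or the length of its chain accounts for the step. An ethyl or propyl chain joined directly to this carbon, or a shorter methylamino group, would begin to separate the two.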